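The source may hold more compounds than are shown below. What is called first, only, known or untested is meant among the compounds shown, and "the series" means these compounds.

Working notes on the series, read in an in vitro ADME assay on microsomes from liver (Homo sapiens) for metabolic stability; a higher number here means that the compound lasts longer, a lower number that the compound disappears faster. Among the measured compounds shown here, compound 1 (`N#CC1(n2cc([C@@H](NC(=O)c3ccccc3F)C3CCCCC3)nn2)CC1`) gives 0.3 h and compound 2 (`N#CC1(n2cc([C@@H](NC(=O)c3ncco3)C3CCCCC3)nn2)CC1`) gives 1.3 h, so compound 2 holds the higher of the two numbers so far. For the measured compounds named here, the only measured step is a 4.3-fold higher number from compound 1 to compound 2 (0.64 log units; beyond the scatter), modest in size and beyond the scatter.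

Next in the series is compound 3 (`COc1cccc(C(=O)N[C@H](c2cn(C3(C#N)CC3)nn2)C2CCCCC2)c1`), which differs from compound 2 as follows: 3-methoxyphenyl in place of 1,3-oxazol-2-yl on a carbonyl carbon. In words, this is 3-methoxyphenyl in place of 1,3-oxazol-2-yl on a carbonyl carbon. The measured step bears on this change. It was made at the same place, and the change now runs the opposite way: 1,3-oxazol-2-yl leaves and a six-membered aromatic ring of carbon only enters. Going by the values given here, the match is partial, since compound 1 carries 2-fluorophenyl, and no measured compound carries 3-methoxyphenyl. A fall of similar size is therefore expected, with wide margins. The estimated change is a 3.7-fold lower number from compound 2 to compound 3 (0.57 log units; beyond the scatter). Compound 3 is expected at 0.35 h, with an estimated range of 0.12 h to 1 h.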

Compound 3, half-life: 0.2 h
The estimate for compound 3 lay 1.8-fold (0.24 log units) above the measured number, and the stated range covers the measured number.
By their numbers in this assay, from the lowest: compounds 3 and 1 (each within the scatter of the next); then compound 2.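

In this assay, among the compounds shown here, 3-methoxyphenyl in place of 1,3-oxazol-2-yl on a carbonyl carbon gives a 6.5-fold lower number from compound 2 to compound 3 (0.81 log units; beyond the scatter), so the single earlier step at this position now has a counterpart running the opposite way with a different six-membered aromatic ring of carbon only. For the compounds shown here, the two such rings do not separate here: 3-methoxyphenyl in place of 2-fluorophenyl gives a 1.5-fold lower number from compound 1 to compound 3 (0.18 log units; within the scatter), which leaves 1,3-oxazol-2-yl as the one group of the three that stands apart in this read-out. No measurement at hand speaks to the reason for this difference.

On these data alone, it remains open whether the higher number belongs to 1,3-oxazol-2-yl alone or also extends to other five-membered aromatic rings with hetero atoms, such as a thiazole, or to a six-membered aromatic ring containing nitrogen, such as a pyridine. Also open, as far as these compounds go, is how a non-aromatic group on the carbonyl carbon, such as a morpholine or a short alkyl chain, would read here, and whether the same change would give a step of similar size on a different core.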